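This account rests on a few compounds, and the source may have more. Where it says the series, first, only, none or still open, it means among the compounds named here.

Of the compounds shown here, three that share one core have been tested in a functional assay on SW982 cells (Homo sapiens) for inhibition, read by MTT assay, with a stated time of 72 h; a lower number here means a stronger inhibitor, a higher number a weaker inhibitor. Compound 1 `COc1cc(OC)c(OC)cc1/C=C/C(=O)c1cc(Cl)ccc1O` gives > 150000 nM, which is a limit of the assay and not a number. Compound 3 `COc1cc(OC)c(OC)cc1/C=C/C(=O)c1cccc(C(F)(F)F)c1` gives > 150000 nM, which is also a limit. Compound 1 therefore stands at the limit of > 150000 nM in this assay, at which 2 of the 3 values shown sit. Compound 2 `COc1cc(OC)c(OC)cc1/C=C/C(=O)c1ccc(Cl)c([N+](=O)[O-])c1` is the only one of the three with an actual number, 20600 nM.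

The next compound to consider is compound 4 `COc1cc(OC)c(OC)cc1/C=C/C(=O)c1ccc(Br)cc1`, which has not yet been measured. It carries 4-bromophenyl in place of the 5-chloro-2-hydroxyphenyl of compound 1, on a carbonyl carbon (4-bromophenyl in place of 5-chloro-2-hydroxyphenyl on a carbonyl carbon). For the measured compounds named here, no measured pair in this small set isolates a single change, so no direct precedent exists for this step.

The two kinds of result still frame an expectation. Compound 2, at 20600 nM, shows that the shared core can give a number in this assay, so a modest shift towards a lower number is expected for compound 4. Because of the limit of > 150000 nM in this assay, at which 2 of the 3 values shown sit, staying at the limit remains a real possibility. The expected step, an at least 2.1-fold lower number from compound 1 to compound 4 (0.33 log units; beyond the scatter), is therefore small and uncertain. For compound 4 the estimated value is 70000 nM, with an expected range from 18000 nM to 150000 nM.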

Compound 4, half-maximal inhibitory concentration: 38200 nM
The estimate for compound 4 lay 1.8-fold (0.26 log units) above the measured number; the range from low to high includes it.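

Swapping 5-chloro-2-hydroxyphenyl for 4-bromophenyl on the carbonyl carbon gives an at least 3.9-fold lower number from compound 1 to compound 4 (0.59 log units; beyond the scatter), the first step in this assay that can be read between two compounds differing in one place, and it shows that the group at this carbonyl carbon can bring the shared core off the limit and give an actual number. Going by these compounds, compound 1 gives > 150000 nM, which is a limit and not a number, so the step sets only a minimum size, and its true size stays unknown because of this limit: the limit of > 150000 nM in this assay, at which 2 of the 4 values shown sit. The swap also removes the hydroxy group and the chlorine and brings in bromine, all in one step, so the result belongs to the whole group and not to any one of these parts.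

Compound 3, which also has no hydroxy group on that ring, gives > 150000 nM, again a limit and not a number, so losing the hydroxy group cannot be read as enough by itself. The compounds shown leave open which part of 4-bromophenyl matters, and how the number would move with an amine or a carboxylic acid on this ring.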